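Cytotoxicity notes: replacing the cyano group on the pyrrolidinone

The source may hold more compounds than are shown below. What is called first, only, known or untested is meant among the compounds shown, and "the series" means these compounds.

Measured so far in a toxicity assay on HepG2 2.2.15 cells (Homo sapiens) for cytotoxicity, read by CellTiter-Glo; a lower number here means that less compound is tolerated, a higher number that more compound is tolerated:
- compound 1 `N#CC1CC(=O)N(c2cnn3c2CN(C(=O)Nc2cc(F)c(F)c(F)c2)C(C2CC2)C3)C1`: > 200000 nM.
- compound 2 `O=C1CC(Oc2ncc(F)cn2)CN1c1cnn2c1CN(C(=O)Nc1cc(F)c(F)c(F)c1)C(C1CC1)C2`: 96200 nM.
- compound 3 `O=C1CC(c2ccc(F)cc2)CN1c1cnn2c1CN(C(=O)Nc1cc(F)c(F)c(F)c1)C(C1CC1)C2`: 32100 nM.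

Compound 1 in this assay stands at a limit of the assay and not a number (the limit of > 200000 nM in this assay, at which 1 of the 3 values shown sits). Compound 2 in this assay gives 96200 nM, and compound 3 gives 32100 nM; both sit below the limit, with an at least 2.0-fold lower number from compound 1 to compound 2 (0.31 log units; beyond the scatter), an at least 6.2-fold lower number from compound 1 to compound 3 (0.79 log units; beyond the scatter) and a 3.0-fold lower number from compound 2 to compound 3 (0.48 log units; beyond the scatter).

Compound 4 `O=C1CC(c2nccs2)CN1c1cnn2c1CN(C(=O)Nc1cc(F)c(F)c(F)c1)C(C1CC1)C2` differs from compound 1 by 1,3-thiazol-2-yl in place of cyano on a saturated ring carbon. The two measured steps from compound 1 bear on it, since each replaces cyano on the same saturated ring carbon; the larger drop came with the aromatic ring of compound 3, and 1,3-thiazol-2-yl is likewise an aromatic ring. A lower number than for compound 1 is therefore expected, beyond the scatter, roughly between the results of compound 2 and compound 3. The expected step is an at least 4.0-fold lower number from compound 1 to compound 4 (0.60 log units; beyond the scatter). Compound 4 is estimated at 50000 nM, in the range 20000 nM to 150000 nM.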

Compound 4, half-maximal cytotoxic concentration: 115000 nM
For compound 4 the middle estimate is 2.3-fold (0.36 log units) below the measured one, within the range that was stated.
By their numbers in this assay, from the lowest: compound 3; then compounds 2 and 4 (each within the scatter of the next). At a limit, above all of these: compound 1.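

In this assay, 1,3-thiazol-2-yl on this saturated ring carbon gives a 3.6-fold higher number from compound 3 to compound 4 (0.55 log units; beyond the scatter), so an aromatic ring there does not by itself bring the number down to that of compound 3. The same group gives a 1.2-fold higher number from compound 2 to compound 4 (0.08 log units; within the scatter), so it cannot be told apart here from (5-fluoropyrimidin-2-yl)oxy. Its step from cyano is only a floor, an at least 1.7-fold lower number from compound 1 to compound 4 (0.24 log units; that floor lies within the scatter), so, unlike for compound 2 and compound 3, a change beyond the scatter is not established.

As far as these compounds go, compound 1 is held only as a limit of the assay and not a number, so the true size of every step from it stays open: the limit of > 200000 nM in this assay, at which 1 of the 4 values shown sits. Also open is how an amine or a carboxylic acid on this carbon would read in this assay.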